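Phenyl for thiophen-3-yl at the edge of the assay

The source may hold more compounds than are shown below. What is called first, only, known or untested is meant among the compounds shown, and "the series" means these compounds.

In a functional assay on CEM-DNR-bulk cells (Homo sapiens), read by MTT assay, with a stated time of 72 h (on this read-out higher numbers stand for weaker inhibition and lower numbers for stronger inhibition), compound 1 `Cc1nc(N)c2c(-c3ccoc3)cn([C@@H]3O[C@H](CO)[C@@H](O)[C@H]3O)c2n1`, which carries furan-3-yl on the shared core, gives > 20000 nM, a limit of the assay and not a number. Compound 2 `Cc1nc(N)c2c(-c3cccs3)cn([C@@H]3O[C@H](CO)[C@@H](O)[C@H]3O)c2n1`, with thiophen-2-yl in that place, gives > 20000 nM, again a limit. Compound 3 `Cc1nc(N)c2c(-c3ccsc3)cn([C@@H]3O[C@H](CO)[C@@H](O)[C@H]3O)c2n1`, with thiophen-3-yl, gives > 20000 nM, also a limit. Compound 3 therefore has no exact number, and the whole set reads alike: the limit of > 20000 nM in this assay, at which 3 of the 3 values shown sit.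

Compound 4 `Cc1nc(N)c2c(-c3ccccc3)cn([C@@H]3O[C@H](CO)[C@@H](O)[C@H]3O)c2n1` puts phenyl in place of thiophen-3-yl on an aromatic carbon. A six-membered aromatic ring of carbon only thus replaces a five-membered aromatic ring with one hetero atom.

The nearest guides are the swaps of this same group: a step that the two limits leave unreadable from compound 1 to compound 2, a step that the two limits leave unreadable from compound 1 to compound 3 and a step that the two limits leave unreadable from compound 2 to compound 3. None of these has a readable size, but none of the three swaps produced an exact number. A six-membered ring has not yet been measured here, so this guidance is limited.

No step beyond the usual scatter is expected in either direction, and the estimated change is a number no higher from compound 3 to compound 4 (the limit leaves the size open). Compound 4 is expected to read about 20000 nM, with an estimated range from 7000 nM to 30000 nM.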

Compound 4, half-maximal inhibitory concentration: > 20000 nM
Compound 4 ended at the assay's limit (the forecaster's own chance of this, stated with the estimate: 85%); the middle value sits exactly at the limit.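

Compound 4 also stops at a limit, so none of the steps from compound 1, compound 2 or compound 3 to compound 4 can be read, and the four compounds cannot be ranked: the limit of > 20000 nM in this assay, at which 4 of the 4 values shown sit.

The compounds shown leave open how strongly each one really inhibits, and whether furan-3-yl, thiophen-2-yl, thiophen-3-yl and phenyl differ at all in this assay.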